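A few compounds are considered here, and "the series" means these few. Any claim that something is new, unique, unknown or untested is made for them only; others in the source may bear on it.

Going by the values given here, compound 3 `COc1cc2c(Oc3ccc(NC(=O)c4nn(-c5cccc(C)c5)cc(C)c4=O)cc3)ccnc2cc1OCCCCCCC(=O)NO` gives 280 nM in a functional assay on A549 cells (Homo sapiens) for inhibition, read by MTT assay, with a stated time of 72 h (on this read-out higher numbers stand for weaker inhibition and lower numbers for stronger inhibition), the lowest of the three numbers so far. Compound 2 `COc1cc2c(Oc3ccc(NC(=O)c4nn(-c5ccccc5)cc(C)c4=O)cc3)ccnc2cc1OCCCCCCC(=O)NO` gives 420 nM. The step of a 1.5-fold lower number from compound 2 to compound 3 (0.18 log units; within the scatter) stays within the scatter. Compound 1 `COc1cc2c(Oc3ccc(NC(=O)c4nn(-c5ccccc5C)cc(C)c4=O)cc3)ccnc2cc1OCCCCCC(=O)NO` gives 1820 nM, a clearly higher number, but it differs from compound 3 in two places, so that gap cannot be assigned to either change. Compound 4 `COc1cc2c(Oc3ccc(NC(=O)c4nn(-c5ccc(C)cc5C)cc(C)c4=O)cc3)ccnc2cc1OCCCCCCC(=O)NO` carries 2,4-dimethylphenyl in place of 3-methylphenyl on an aromatic nitrogen. Among the compounds with values here, the only measured step that bears on this, a 1.5-fold lower number from compound 2 to compound 3 (0.18 log units; within the scatter), was within the scatter, and no measured step isolates the change now made. For compound 4 the expected step is therefore a 1.4-fold higher number from compound 3 to compound 4 (0.15 log units; within the scatter), nothing beyond the scatter in this assay. Compound 4 is estimated at 400 nM, with a range from 150 nM to 1100 nM.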

Compound 4, half-maximal inhibitory concentration: 1840 nM
Beside the measured number, compound 4's estimate is 4.6-fold (0.66 log units) below it; the whole stated range lies below it.
By their numbers in this assay, from the lowest: compounds 3 and 2 (each within the scatter of the next); then compounds 1 and 4 (each within the scatter of the next).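

In this assay the aryl group on the aromatic nitrogen proves able to move the number: 2,4-dimethylphenyl in place of 3-methylphenyl gives a 6.6-fold higher number from compound 3 to compound 4 (0.82 log units; beyond the scatter) and 2,4-dimethylphenyl in place of phenyl gives a 4.4-fold higher number from compound 2 to compound 4 (0.64 log units; beyond the scatter) with both steps beyond the scatter. Going by these compounds alone, the earlier change at this position, 3-methylphenyl in place of phenyl, stayed within the scatter, so this is the first change here with a readable effect.

Which of the two methyl groups carries the rise stays open, as does the outcome with an amine or a carboxylic acid on this phenyl ring. Nothing available explains the rise.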